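The source may report more compounds than this note shows. Statements on the series, on what has been measured and on what is new or still open speak of the compounds shown alone.

Working notes on the series. Compound 3 `CC(C)C(c1ccc(-c2ccc3cccc(F)c3c2)[nH]c1=O)N1CCN/C1=N\C#N` holds the highest number of the three measured in an ADME assay on microsomes from liver (Rattus norvegicus) for metabolic stability; a lower number here means that the compound disappears faster, a higher number that the compound lasts longer: compound 3 gives 0.327 h. Its nearest neighbour is compound 2 `CC(C)C(c1ccc(-c2ccc3cccc(F)c3c2)[nH]c1=O)N1CCNC1=O`, for which this assay gives 0.283 h; the gap, a 1.2-fold higher number from compound 2 to compound 3 (0.06 log units; within the scatter), stays within the scatter. Furthest away lies compound 1 `CC(C)C(Nc1nccs1)c1ccc(-c2ccc3cccc(F)c3c2)[nH]c1=O`, which in this assay gives 0.07 h. Both steps away from compound 1 are beyond the scatter: a 4.0-fold higher number from compound 1 to compound 2 (0.61 log units; beyond the scatter) and a 4.7-fold higher number from compound 1 to compound 3 (0.67 log units; beyond the scatter).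

Compound 4 `CC(C)C(CC(N)=O)c1ccc(-c2ccc3cccc(F)c3c2)[nH]c1=O` is not yet measured. Its change from compound 3: a group of 4 heavy atoms (2 carbon, 1 nitrogen, 1 oxygen; no ring) in place of a group of 8 heavy atoms (4 carbon, 4 nitrogen; one five-membered non-aromatic ring with 2 hetero atoms), on a saturated chain carbon bound to an aromatic carbon and a saturated chain carbon. Among the measured compounds shown here, no measured step trades a ring for a group with no ring at this saturated chain carbon, so nothing in the set bears on it directly. The steps that do touch this position were modest, and the exchange between the two non-aromatic rings stayed within the scatter. Compound 4 is therefore expected close to compound 3, the step of a 1.3-fold lower number from compound 3 to compound 4 (0.12 log units; within the scatter) not clearly beyond the scatter. Compound 4 is estimated at 0.25 h, in a range from 0.1 h to 0.6 h.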

Compound 4, half-life: < 0.0667 h
Compound 4 ended at the assay's limit; the forecaster's own chance of this, stated with the estimate: 5%; at least 3.7-fold (0.57 log units) between middle value and limit.
By their numbers in this assay, from the lowest: compound 1; then compounds 2 and 3 (each within the scatter of the next). At a limit, below all of these: compound 4.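

Compound 4 stands at a limit of this assay, not at a number: the limit of < 0.0667 h in this assay, at which 1 of the 4 values shown sits. The saturated chain carbon is not indifferent to what it carries: the exchange between the two non-aromatic rings stayed within the scatter, whereas carbamoylmethyl, with no ring, gives an at least 4.9-fold lower number from compound 3 to compound 4 (0.69 log units; beyond the scatter) and an at least 4.2-fold lower number from compound 2 to compound 4 (0.62 log units; beyond the scatter). Against the (1,3-thiazol-2-yl)amino group the reading is only a floor, an at least 1.0-fold lower number from compound 1 to compound 4 (0.02 log units; that floor lies within the scatter), so these two groups are not separated in this assay.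

Going by these compounds, how far compound 4 lies past its limit stays unknown. Also open, on these data alone, is whether the ring itself or the carbamoylmethyl group decides the outcome: a pyrrolidinone ring, a carboxylic acid or an amine on this carbon would bear on that.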